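This account rests on a few compounds, and the source may have more. Where it says the series, first, only, none or still open, it means among the compounds named here.

Compound 1 `CCCCCCCCNC(=N)N1C[C@H](O)[C@@H](O)[C@H](O)[C@H]1CO` in an assay for inhibition of beta-galactosidase (Bos taurus), read by spectrophotometry, with a stated time of 30 min (on this read-out higher numbers stand for weaker inhibition and lower numbers for stronger inhibition), gives 2600 nM. Compound 2 `N=C(NCCOCCO)N1C[C@H](O)[C@@H](O)[C@H](O)[C@H]1CO` gives in this assay only a limit of the assay, > 1000000 nM. The step between them, an at least 380-fold higher number from compound 1 to compound 2 (2.58 log units; beyond the scatter), shows a large loss of inhibition when the hexyl chain is exchanged. Compound 3 `N=C(NCCO)N1C[C@H](O)[C@@H](O)[C@H](O)[C@H]1CO` differs from compound 2 by hydrogen in place of 2-hydroxyethyl on an oxygen on a saturated carbon, a further shortening of the same chain. Among the compounds with values here, with the only measured step so large and toward weaker inhibition, no return to measurable inhibition is expected, and the expected step is a step that the limit leaves unreadable from compound 2 to compound 3. Compound 3 is estimated at 2000000 nM, between 200000 nM and 20000000 nM, most likely reported again only as a limit.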

Compound 3, half-maximal inhibitory concentration: > 1000000 nM
Compound 3: only a limit was reported; the forecaster's own chance of this, stated with the estimate: 85%; the middle value does not contradict the limit.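

Replacing hexyl with hydroxy on the chain gives an at least 380-fold higher number from compound 1 to compound 3 (2.58 log units; beyond the scatter), so the shorter hydroxy-ended chain also lacks the measurable inhibition of compound 1. In this assay, compound 3 gives > 1000000 nM, a limit of the assay and not a number. The step between compound 2 and compound 3 cannot be read, because both compounds sit at the same limit: the limit of > 1000000 nM in this assay, at which 2 of the 3 values shown sit.

Removing 2-hydroxyethyl therefore shows no return of measurable inhibition, but any difference beyond the limit stays hidden. Still open, as far as these compounds go, is how a plain butyl chain, or a longer chain ending in an amine, would compare with compound 1.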